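A few compounds are considered here, and "the series" means these few. Any claim that something is new, unique, unknown or untested is made for them only; others in the source may bear on it.

Compound 3 `CN(C)/C(=N/CCCCCn1nc(-c2ccccc2)ccc1=O)NC#N` gives 53.1 mg/kg in a functional assay on the whole organism with Rattus norvegicus as the target; a higher number here means that more compound is needed for the effect, a lower number that less compound is needed. Among the three numbers measured it is the second highest: compound 2 `CC/N=C(/NC#N)NCCCCCn1nc(-c2ccccc2)ccc1=O` gives 60.3 mg/kg and compound 1 `C/N=C(\S)NCCCCCn1nc(-c2ccccc2)ccc1=O` gives 42.1 mg/kg; the steps are a 1.1-fold lower number from compound 2 to compound 3 (0.06 log units; within the scatter) and a 1.3-fold higher number from compound 1 to compound 3 (0.10 log units; within the scatter), and a 1.4-fold higher number from compound 1 to compound 2 (0.16 log units; within the scatter) is likewise within the scatter. Compound 4 `CN(C)/C(=N/CCCCCCn1nc(-c2ccccc2)ccc1=O)NC#N` differs from compound 3 by a group of 9 heavy atoms (5 carbon, 4 nitrogen; no ring) in place of a group of 8 heavy atoms (4 carbon, 4 nitrogen; no ring), on a saturated chain carbon, five bonds along the chain from an aromatic nitrogen, that is, a longer chain carrying the same end group. Among the compounds with values here, none of the measured steps alters the chain; all three exchange the group at that same place, and all three lie within the scatter, so the step of a 1.0-fold lower number from compound 3 to compound 4 (0.00 log units; within the scatter) is expected to stay within the scatter, with no direction favoured. Compound 4 is therefore estimated at 53 mg/kg in this assay, with a range from 25 mg/kg to 110 mg/kg.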

Compound 4, dose for half-maximal effect: 92.5 mg/kg
Compound 4: the middle estimate sits 1.7-fold (0.24 log units) below what was measured, within the range that was stated.
By their numbers in this assay, from the lowest: compounds 1, 3, 2 and 4 (each within the scatter of the next, the first and the last beyond it).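

In this assay, within the data shown here, the only step that alters the chain while keeping the end group is a 1.7-fold higher number from compound 3 to compound 4 (0.24 log units; within the scatter), so lengthening at this place stays inside the scatter. Among these compounds, changing the chain and the end group together gives a 1.5-fold higher number from compound 2 to compound 4 (0.19 log units; within the scatter), whereas a 2.2-fold higher number from compound 1 to compound 4 (0.34 log units; beyond the scatter) is the only step here beyond the scatter, and it is modest and cannot be assigned to either change alone. Nothing available bears on the cause of these steps.

Still open, going by these compounds, is whether a longer chain than that of compound 4 moves the number further. The end group of compound 1 on the chain of compound 4 would separate the two changes.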